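From Methyl to Ethyl: Expecting the Activity of Compound 4

The source may report more compounds than this note shows. Statements on the series, on what has been measured and on what is new or still open speak of the compounds shown alone.

Of the compounds shown here, three sharing one core have been measured in a functional assay on A-431 cells (Homo sapiens) for antiproliferative activity, read by MTT assay, with a stated time of 72 h; a higher number here means a weaker inhibitor, a lower number a stronger inhibitor. Compound 1 `NS(=O)(=O)c1ccc(NC(=S)Nc2ccc3ncnc(Nc4cccc(C(F)(F)F)c4)c3c2)cc1` gives 21700 nM. Compound 2 `NS(=O)(=O)c1ccc(NC(=S)Nc2ccc3ncnc(Nc4cccc(Br)c4)c3c2)cc1` gives 20700 nM in this assay. Compound 3 `Cc1ccc(Nc2ncnc3ccc(NC(=S)Nc4ccc(S(N)(=O)=O)cc4)cc23)cc1` gives 40000 nM in this assay. Compound 3 holds the highest of the three numbers, yet its distance to its nearest neighbour is a 1.8-fold higher number from compound 1 to compound 3 (0.27 log units; within the scatter) and to the furthest is a 1.9-fold higher number from compound 2 to compound 3 (0.29 log units; within the scatter), both within the scatter, so no order among the three can be read from these values. The step of a 1.0-fold lower number from compound 1 to compound 2 (0.02 log units; within the scatter) is likewise within the scatter.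

Compound 4 `CCc1ccc(Nc2ncnc3ccc(NC(=S)Nc4ccc(S(N)(=O)=O)cc4)cc23)cc1` differs from compound 3 by methyl in place of hydrogen on a saturated chain carbon bound to an aromatic carbon. Among the measured compounds shown here, none of the measured steps touches this exact spot. The two steps that alter the same aryl part of the molecule, a 1.8-fold higher number from compound 1 to compound 3 (0.27 log units; within the scatter) and a 1.9-fold higher number from compound 2 to compound 3 (0.29 log units; within the scatter), each stay within the scatter, and the exchange of one substituent for another in a 1.0-fold lower number from compound 1 to compound 2 (0.02 log units; within the scatter) does too. With three changes on this part of the structure leaving the numbers flat, the step to compound 4 is expected to be a 1.1-fold lower number from compound 3 to compound 4 (0.06 log units; within the scatter), meaning nothing beyond the scatter. Compound 4 is therefore estimated at 35000 nM in this assay, with a range from 15000 nM to 90000 nM.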

Compound 4, half-maximal inhibitory concentration: 38400 nM
Compound 4: middle estimate off by 1.1-fold (0.04 log units), on the low side, within the range that was stated.
By their numbers in this assay, from the lowest: compounds 2, 1, 4 and 3 (each within the scatter of the next).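

In this assay, the step at the saturated chain carbon bound to an aromatic carbon is a 1.0-fold lower number from compound 3 to compound 4 (0.02 log units; within the scatter), so extending 4-methylphenyl to 4-ethylphenyl leaves the number flat. The earlier steps shown here exchanged one whole aryl group for another, whereas this one isolates the addition of methyl at this place. The new group also stays level with the other two aryl groups, at a 1.9-fold higher number from compound 2 to compound 4 (0.27 log units; within the scatter) and a 1.8-fold higher number from compound 1 to compound 4 (0.25 log units; within the scatter), and no evidence bears on the cause of this flat result.

On these data alone, whether the reading stays flat with a longer chain such as propyl or butyl, with a branched group such as isopropyl, or with an amine or a carboxylic acid carried on the same chain remains open. The four compounds differ only in this aryl group, so they also leave open whether any change elsewhere on the shared core would move the number beyond the scatter.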